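A Nitro Group Enters a Flat Anticonvulsant Series

A few compounds are considered here, and "the series" means these few. Any claim that something is new, unique, unknown or untested is made for them only; others in the source may bear on it.

Three compounds have been tested in a functional assay on the whole organism (strain Swiss albino) with Mus musculus as the target, in the maximal electroshock model, with a stated time of 4 h; a lower number here means that less compound is needed, a higher number that more compound is needed for the effect:
Compound 1, `O=C(N/N=C\c1cccc(O)c1)Nc1nnc(COc2ccc3ccccc3c2)o1`: 300 mg/kg
Compound 2, `O=C(N/N=C\c1ccc(O)cc1)Nc1nnc(COc2ccc3ccccc3c2)o1`: 300 mg/kg
Compound 3, `O=C(NN=C(c1ccccc1)c1ccccc1)Nc1nnc(COc2ccc3ccccc3c2)o1`: 300 mg/kg

Compound 3 stands level with compounds 1 and 2 on these numbers; its nearest neighbour is compound 1 and its furthest is compound 2, both within the scatter. Within the data shown here, the only single-point step measured so far, no change at the digits printed from compound 1 to compound 2 (within the scatter), exchanged one hydroxyphenyl for another and left the reading unchanged. Compound 4, `O=C(N/N=C(/c1ccccc1)c1ccc([N+](=O)[O-])cc1)Nc1nnc(COc2ccc3ccccc3c2)o1`, differs from compound 3 by nitro in place of hydrogen on an aromatic carbon. Among the measured compounds shown here, no measured step involves a nitro group, so the one known step shows only that this series has so far not responded to a change on an aromatic ring. The step from compound 3 to compound 4 is therefore expected to be no change at the digits printed from compound 3 to compound 4 (within the scatter), none beyond the scatter. For compound 4 the expected value in this assay is 300 mg/kg, with a range from 150 mg/kg to 600 mg/kg.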

Compound 4, minimum effective dose: 300 mg/kg
Compound 4: the middle estimate sits on the measured number at the digits printed, within the range that was stated.
By their numbers in this assay, from the lowest: compounds 1, 2, 3 and 4 (each within the scatter of the next).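

In this assay, a nitro group placed on an aromatic carbon, para to a large group, brings no change at the digits printed from compound 3 to compound 4 (within the scatter). Where the earlier step only exchanged one hydroxyphenyl for another, this one adds a group of 3 heavy atoms to the ring, and the reading still holds. Nothing available offers an explanation for this result. Going by these compounds, whether an amine or a carboxylic acid at this position would also leave the reading unchanged remains open.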